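The compounds below may be only part of what the source reports. "The series", "measured", "known", "first", "only" and "open" are said of these compounds alone.

Compounds measured in a functional assay on G-361 cells (Homo sapiens) for cytotoxicity, read by sulforhodamine B assay; a higher number here means that more compound is tolerated, a lower number that less compound is tolerated:
compound 1 `Cc1nc(NC(C)C)c2cnn(-c3ccccc3)c2n1` — > 100000 nM
compound 2 `CCc1nc(NC(C)C)c2cnn(-c3ccccc3)c2n1` — > 100000 nM
compound 3 `CC(C)NCc1nc(NC(C)C)c2cnn(-c3ccccc3)c2n1` — not yet measured

In this assay compound 1 gives > 100000 nM, which is a limit of the assay and not a number. In this assay compound 2 gives > 100000 nM, again only a limit. Compound 2 thus stands at the ceiling of what the assay reports, together with the other measured compound: the limit of > 100000 nM in this assay, at which 2 of the 2 values shown sit. For the measured compounds named here, the one measured step, a step that the two limits leave unreadable from compound 1 to compound 2, is therefore of unknown size.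

Compound 3 differs from compound 2 by isopropylamino in place of methyl on a saturated chain carbon bound to an aromatic carbon. Going by the values given here, the only step that bears on this change is the one from compound 1 to compound 2, which alters the same saturated chain carbon; it could not be sized, so it gives no direction for this assay. The entering group is larger and brings a donor and an acceptor, but no measured value shows what that does here. No step beyond the scatter is expected; the estimated step is a number no higher from compound 2 to compound 3 (the limit leaves the size open). For compound 3 the expected value in this assay is 100000 nM, with a range from 30000 nM to 300000 nM, most likely reported once more as a limit.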

Compound 3, concentration lethal to 50% of the cells: > 100000 nM
Compound 3: a limit, no number (the forecaster's own chance of this, stated with the estimate: 75%); the middle value sits exactly at the limit.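

In this assay compound 3 gives > 100000 nM, a limit and not a number. No step among compound 1, compound 2 and compound 3 can be read, because all three share one limit: the limit of > 100000 nM in this assay, at which 3 of the 3 values shown sit.

The compounds shown leave open whether methyl or isopropylamino on the saturated chain carbon changes the read-out at all.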